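A pyridyl ring in place of the alkyne chain

The source may report more compounds than this note shows. Statements on the series, on what has been measured and on what is new or still open speak of the compounds shown alone.

Compound 1 `Nc1ccc(S(=O)(=O)N2CCN(c3ncc(C(O)(C(F)(F)F)C(F)(F)F)cc3Br)CC2)cn1` and compound 2 `Nc1ccc(S(=O)(=O)N2CCN(c3ncc(C(O)(C(F)(F)F)C(F)(F)F)cc3C#CCCO)CC2)cn1` share one core. In an ADME assay (liver) for metabolic stability, with Liver microsome (Homo sapiens) as the target, using microsomes and NADPH, with a stated time of 30 min, tested at 1 uM (on this read-out higher numbers stand for fast clearance and lower numbers for slow clearance), compound 1 gives < 14 mL.min-1.g-1, which is a limit of the assay rather than a number. In this assay compound 2 gives < 14 mL.min-1.g-1, likewise a limit. The step that the two limits leave unreadable from compound 1 to compound 2 is therefore not readable, and compound 2 stands where both shown values sit (the limit of < 14 mL.min-1.g-1 in this assay, at which 2 of the 2 values shown sit). Compound 3 `Cc1ccc(-c2cc(C(O)(C(F)(F)F)C(F)(F)F)cnc2N2CCN(S(=O)(=O)c3ccc(N)nc3)CC2)cn1` differs from compound 2 by 6-methylpyridin-3-yl in place of 4-hydroxybut-1-yn-1-yl on an aromatic carbon. No measured step bears directly on this change, since the one step shown is unreadable and both values rest at the limit (the limit of < 14 mL.min-1.g-1 in this assay, at which 2 of the 2 values shown sit). The step expected from compound 2 to compound 3 is a step that the limit leaves unreadable from compound 2 to compound 3, nothing beyond the scatter. Compound 3 is estimated to give 10 mL.min-1.g-1 in this assay, within a range from 4 mL.min-1.g-1 to 28 mL.min-1.g-1.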

Compound 3, intrinsic clearance in microsomes: 43 mL.min-1.g-1
The estimate for compound 3 lay 4.3-fold (0.63 log units) below the measured number; the measured number lies above the stated range.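

In this assay the change to 6-methylpyridin-3-yl on this aromatic carbon, ortho to a large group, brings an at least 3.0-fold higher number from compound 2 to compound 3 (0.48 log units; beyond the scatter) and also an at least 3.0-fold higher number from compound 1 to compound 3 (0.48 log units; beyond the scatter) when bromo is the group replaced. The group at this position can therefore move the read-out, which the step from bromo to 4-hydroxybut-1-yn-1-yl, unreadable as it is, could not show. Going by these compounds alone, compound 3 is the only compound here with a number rather than a limit, and both steps are known only as minimum sizes because the two earlier values are limits: the limit of < 14 mL.min-1.g-1 in this assay, at which 2 of the 3 values shown sit.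

The compounds shown do not separate the ring from its methyl group; a plain pyridin-3-yl or phenyl ring on this carbon would do so. Nor do they tell how an amine or a saturated hydroxybutyl chain here would read in this assay against compound 3.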